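Thiazolyl on the Sulfonamide Nitrogen of Compound 3

The source may report more compounds than this note shows. Statements on the series, on what has been measured and on what is new or still open speak of the compounds shown alone.

Compound 3 `NS(=O)(=O)c1ccc(Nc2nncc3ccccc23)cc1` carries an unsubstituted sulfonamide, and in a functional assay on HT-29 cells (Homo sapiens) for antiproliferative activity, read by sulforhodamine B assay, with a stated time of 72 h (a higher number here means a weaker inhibitor, a lower number a stronger inhibitor), compound 3 gives 12 nM, the lowest of the three numbers shown. Its companions are compound 1 `Cc1cc(NS(=O)(=O)c2ccc(Nc3nncc4ccccc34)cc2)no1`, which in this assay gives 23 nM, and compound 2 `O=S(=O)(Nc1ccccn1)c1ccc(Nc2nncc3ccccc23)cc1`, which in this assay gives 38 nM. Compound 4 `O=S(=O)(Nc1nccs1)c1ccc(Nc2nncc3ccccc23)cc1` differs from compound 3 in one place: 1,3-thiazol-2-yl in place of hydrogen on a sulfonamide nitrogen. Within the data shown here, two measured steps bear on this change, both read in the opposite direction: a 1.9-fold lower number from compound 1 to compound 3 (0.28 log units; within the scatter), and a 3.2-fold lower number from compound 2 to compound 3 (0.50 log units; beyond the scatter). Placing an aromatic ring on the sulfonamide nitrogen has thus gone with a higher number in both cases, once within the scatter and once modestly beyond it. A similar, modest rise is expected here: a 2.1-fold higher number from compound 3 to compound 4 (0.32 log units; beyond the scatter). For compound 4 the estimate in this assay is 25 nM, with a range from 10 nM to 60 nM.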

Compound 4, half-maximal inhibitory concentration: 34 nM
The estimate for compound 4 lay 1.4-fold (0.13 log units) below the measured number, and the stated range covers the measured number.
By their numbers in this assay, from the lowest: compounds 3, 1, 4 and 2 (each within the scatter of the next, the first and the last beyond it).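

In this assay, 1,3-thiazol-2-yl on the sulfonamide nitrogen gives a 2.8-fold higher number from compound 3 to compound 4 (0.45 log units; beyond the scatter), so a third aromatic ring goes with a higher number than hydrogen, although compound 1 stays within the scatter of compound 3. The identity of the ring makes no readable difference among these three compounds, with a 1.1-fold lower number from compound 2 to compound 4 (0.05 log units; within the scatter) and a 1.5-fold higher number from compound 1 to compound 4 (0.17 log units; within the scatter), both within the scatter. Nothing measured here accounts for the rise that follows from replacing hydrogen with this ring.

The compounds shown leave open whether the rise needs an aromatic ring at all, since the only non-aromatic case on this nitrogen is hydrogen. A methyl group, an acetyl group or a longer chain ending in an amine or a carboxylic acid would test this.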